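Moving the nitro group of compound 3

The source may hold more compounds than are shown below. What is called first, only, known or untested is meant among the compounds shown, and "the series" means these compounds.

Compound 1 `Cc1ccccc1/C(=N/NC(=S)NCCCCCC(=O)NO)c1ccccc1` gives 4220 nM
Compound 2 `O=C(CCCCCNC(=S)N/N=C(\c1ccccc1)c1ccccc1F)NO` gives 6010 nM
Compound 3 `O=C(CCCCCNC(=S)N/N=C(\c1ccccc1)c1ccccc1[N+](=O)[O-])NO` gives 1310 nM

All three values come from a functional assay on K562/A02 cells (Homo sapiens) for antiproliferative activity, read by MTT assay (a lower number here means a stronger inhibitor, a higher number a weaker inhibitor), and compound 3 has the lowest number of the set, clear of both others. Changing the group on the shared core gave a 3.2-fold lower number from compound 1 to compound 3 (0.51 log units; beyond the scatter) with nitro for methyl and a 4.6-fold lower number from compound 2 to compound 3 (0.66 log units; beyond the scatter) with nitro for fluoro, while fluoro for methyl gave a 1.4-fold higher number from compound 1 to compound 2 (0.15 log units; within the scatter) and so no real change. Compound 4 `O=C(CCCCCNC(=S)N/N=C(\c1ccccc1)c1cccc([N+](=O)[O-])c1)NO` has the same atoms as compound 3, joined differently, with 3-nitrophenyl in place of 2-nitrophenyl on a carbon with a double bond to nitrogen as the counted change: 3-nitrophenyl in place of 2-nitrophenyl on a carbon with a double bond to nitrogen. Among the compounds with values here, no measured step moves a group from one place to another, so these steps bear on it only indirectly. Within the data shown here, they show only that the lowest number belongs to the 2-nitrophenyl compound, so a small rise in this assay is expected rather than a further fall. The expected size is a 1.8-fold higher number from compound 3 to compound 4 (0.26 log units; within the scatter) as estimated here, with wide uncertainty. Compound 4 is estimated at 2400 nM with an expected range from 800 nM to 6500 nM for the measurement.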

Compound 4, half-maximal inhibitory concentration: 940 nM
Compound 4: middle estimate off by 2.6-fold (0.41 log units), on the high side, and the stated range covers the measured number.
By their numbers in this assay, from the lowest: compounds 4 and 3 (each within the scatter of the next); then compounds 1 and 2 (each within the scatter of the next).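

In this assay, moving the nitro group gives a 1.4-fold lower number from compound 3 to compound 4 (0.14 log units; within the scatter), so 2-nitrophenyl and 3-nitrophenyl on the carbon with a double bond to nitrogen cannot be told apart in this pair. The lower numbers of the nitro compounds hold after the move, with a 6.4-fold lower number from compound 2 to compound 4 (0.81 log units; beyond the scatter) and a 4.5-fold lower number from compound 1 to compound 4 (0.65 log units; beyond the scatter), so the separation seen for compound 3 is not confined to the 2-nitrophenyl form. Nothing available on these compounds accounts for the lack of a real change on moving the group.

Going by these compounds, it remains open whether a nitrile, a trifluoromethyl group or an amine on the same ring would keep numbers like those of compound 3 and compound 4. Also open, on these data alone, is whether these nitro compounds would keep their numbers with a longer chain on the shared core.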